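A few compounds are considered here, and "the series" means these few. Any claim that something is new, unique, unknown or untested is made for them only; others in the source may bear on it.

Compound 1 `COc1ccc(NS(=O)(=O)/C=C/c2c(OC)cc(OC)cc2OC)cc1` gives 200 nM in a functional assay on DU-145 cells (Homo sapiens) for cytotoxicity, read by trypan blue exclusion, with a stated time of 96 h; on this read-out lower numbers stand for stronger inhibition and higher numbers for weaker inhibition.
Compound 2 `COc1cc(OC)c(/C=C/S(=O)(=O)Nc2ccc(OC)c(N)c2)c(OC)c1` gives 5 nM in this assay.
Compound 3 `COC(=O)C(Nc1cc(NS(=O)(=O)/C=C/c2c(OC)cc(OC)cc2OC)ccc1OC)c1ccccc1` gives 2500 nM in this assay.

Of these three numbers, compound 3 has the highest, meaning the weakest inhibition: its nearest neighbour is compound 1, with a 13-fold higher number from compound 1 to compound 3 (1.10 log units; beyond the scatter), and its furthest is compound 2, with a 500-fold higher number from compound 2 to compound 3 (2.70 log units; beyond the scatter). Compound 4 `COc1cc(OC)c(/C=C/S(=O)(=O)Nc2ccc(OC)c(NC(C(=O)O)c3ccc(Cl)cc3)c2)c(OC)c1` differs from compound 3 in one place: carboxy(4-chlorophenyl)methyl in place of methoxycarbonyl)(benzyl on a nitrogen on an aromatic ring.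

Going by the values given here, two measured steps bear on this. The step of a 500-fold higher number from compound 2 to compound 3 (2.70 log units; beyond the scatter) shows what happens when a hydrogen on that nitrogen is replaced by a group of this size, and the step of a 40-fold lower number from compound 1 to compound 2 (1.60 log units; beyond the scatter) shows how much the free amino group itself contributes. Compound 4 keeps a group of the same size on the same nitrogen, so it is expected to stay far from compound 2. Among the compounds with values here, no measured step compares the two groups that are swapped here, so their difference cannot be read from the data; the number for compound 4 is therefore expected to sit close to compound 3, a step of a 1.2-fold higher number from compound 3 to compound 4 (0.08 log units; within the scatter), within the usual scatter.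

Compound 4 is estimated at 3000 nM, with a range from 800 nM to 12000 nM.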

Compound 4, half-maximal inhibitory concentration: 75 nM
Estimate against measurement, compound 4: 40-fold (1.60 log units) above; the measured number lies below the stated range.
By their numbers in this assay, from the lowest: compound 2; then compound 4; then compound 1; then compound 3.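

In this assay a large group on this nitrogen on an aromatic ring is not in itself ruinous: carboxy(4-chlorophenyl)methyl in place of methoxycarbonyl)(benzyl gives a 33-fold lower number from compound 3 to compound 4 (1.52 log units; beyond the scatter) and the two groups match in heavy-atom count, so the identity of the group matters and not its size alone. The free amino group of compound 2 still remains clearly ahead, with a 15-fold higher number from compound 2 to compound 4 (1.18 log units; beyond the scatter) for this substitution, while the substituted amino group of compound 4 keeps a modest edge over plain hydrogen on the aromatic carbon, with a 2.7-fold lower number from compound 1 to compound 4 (0.43 log units; beyond the scatter) for that change. No measurement shown here accounts for the difference between the two groups.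

The swap changes the methoxycarbonyl to a carboxy group and adds a chlorine on the aromatic ring in one move, so these compounds cannot assign the large step to either change alone. They also leave open how a carboxamide in place of the carboxy group, or a fluorine in place of the chlorine, would behave at this position.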